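The compounds below may be only part of what the source reports. "The series", "measured", "known", "first", "only" and "open" are said of these compounds alone.

Among the measured compounds shown here, in a functional assay on DU-145 cells (Homo sapiens) for inhibition, read by trypan blue exclusion, with a stated time of 96 h (on this read-out lower numbers stand for stronger inhibition of growth and higher numbers for weaker inhibition of growth), compound 1 (`CN(C)c1ccc(/C=C(/SCc2ccc(Br)cc2)C(=O)c2ccc(C(=O)O)cc2)cc1`) gives 50000 nM and compound 2 (`CSc1ccc(/C=C(/SCc2ccc(Br)cc2)C(=O)c2ccc(C(=O)O)cc2)cc1`) gives 10000 nM as the lowest of the two numbers, with compound 1 as its only neighbour. Compound 3 (`CN1CCN(/C=C(/SCc2ccc(Br)cc2)C(=O)c2ccc(C(=O)O)cc2)CC1[N+](=O)[O-]`) is the next case (4-methyl-3-nitropiperazin-1-yl in place of 4-(methylsulfanyl)phenyl on a double-bonded chain carbon bound to a double-bonded chain carbon), with 4-methyl-3-nitropiperazin-1-yl in place of 4-(methylsulfanyl)phenyl on a double-bonded chain carbon bound to a double-bonded chain carbon. For the measured compounds named here, only one measured step bears on this, and only indirectly: a 5.0-fold lower number from compound 1 to compound 2 (0.70 log units; beyond the scatter) with methylsulfanyl in place of dimethylamino on an aromatic carbon, a modest change beyond the scatter. Going by the values given here, that step kept the aromatic ring which compound 3 gives up, and no measured pair shows a swap of this kind. Among the compounds with values here, a step of similar modest size is expected in this assay and it should run towards a higher number, since compound 2 at 10000 nM is the lower of only two values and nothing measured points to a further gain. The expected step is a 3.0-fold higher number from compound 2 to compound 3 (0.48 log units; beyond the scatter) and its uncertainty is wide. For compound 3 the estimate is 30000 nM (expected range 8000 nM to 100000 nM).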

Compound 3, concentration for 50% growth inhibition: 10000 nM
Beside the measured number, compound 3's estimate is 3.0-fold (0.48 log units) above it; the range from low to high includes it.
By their numbers in this assay, from the lowest: compounds 2 and 3 (each within the scatter of the next); then compound 1.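

At this place, on a double-bonded chain carbon bound to a double-bonded chain carbon, the aromatic ring can be given up in this assay without a change beyond the scatter: 4-methyl-3-nitropiperazin-1-yl in place of 4-(methylsulfanyl)phenyl gives no change at the digits printed from compound 2 to compound 3 (within the scatter). The same group in place of 4-(dimethylamino)phenyl gives a 5.0-fold lower number from compound 1 to compound 3 (0.70 log units; beyond the scatter), so among these three compounds only the 4-(dimethylamino)phenyl compound stands apart, and this place accepts a six-membered non-aromatic ring with 2 hetero atoms as well as a six-membered aromatic ring of carbon only. Nothing available explains why the two different rings read alike here.

Going by these compounds, compound 3 alters the ring, the nitro group and the methyl group in a single step, so the share of each stays open, and a plain piperazine or a morpholine at this place would separate the ring from the nitro group. Also open, on these data alone, is how far the result depends on the carboxylic acid of the shared core, which an amide or an ester in its place would test.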